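This account rests on a few compounds, and the source may have more. Where it says the series, first, only, none or still open, it means among the compounds named here.

In an ADME assay on HepG2 cells (Homo sapiens) for cytotoxicity, with a stated time of 72 h (on this read-out higher numbers stand for an effect only at larger amounts of compound and lower numbers for an effect already at smaller amounts), compound 1 `Cc1ccc(NC(=O)Nc2cc(C)nc3ccccc23)cc1` gives > 25000 nM as a limit and not a number. Going by these compounds, compound 2 `Cc1cc(NC(=O)Nc2ccccc2C(C)(C)C)c2ccccc2n1` likewise stands only at a limit, > 25000 nM in this case, so its exact place on the scale is unknown. Compound 3 `Cc1cc(NC(=O)Nc2cccc(C(F)(F)F)c2)c2ccccc2n1` gives 21000 nM as a true number. Compound 4 `Cc1cc(NC(=O)Nc2ccccc2[N+](=O)[O-])c2ccccc2n1` carries nitro in place of tert-butyl on an aromatic carbon, ortho to a large group (nitro in place of tert-butyl on an aromatic carbon), when set against compound 2. Among the compounds with values here, no measured pair differs in one place only, so the effect of this change cannot be read directly. With the limit of > 25000 nM in this assay, at which 2 of the 3 values shown sit, as the main guide, no change beyond the usual scatter is expected, or only a small one toward lower numbers. The step of an at least 1.1-fold lower number from compound 2 to compound 4 (0.05 log units; that floor lies within the scatter) is therefore expected to be small. For compound 4 the estimated value is 22000 nM, with an expected range from 9000 nM to 40000 nM at its ends.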

Compound 4, half-maximal effective concentration: > 25000 nM
Compound 4: a limit, no number; the forecaster's own chance of this, stated with the estimate: 55%; middle value at least 1.1-fold (0.05 log units) from the limit.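

Compound 2 and compound 4 both stand only at a limit, so no step can be read between them. Going by these compounds, what nitro in place of tert-butyl on an aromatic carbon does to the true value stays open.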